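A few compounds are considered here, and "the series" means these few. Any claim that something is new, unique, unknown or untested is made for them only; others in the source may bear on it.

In an ADME assay on Raji cells (Homo sapiens) for cytotoxicity, read by CellTiter-Glo and resazurin assay, with a stated time of 72 h (on this read-out higher numbers stand for an effect only at larger amounts of compound and lower numbers for an effect already at smaller amounts), compound 3 `CCOC(=O)CCCCCOc1cccc(CN(C(=O)c2ccc(-c3ccoc3)cc2)C(C)C)c1` gives > 26000 nM as its reading, which is a limit and not a number. Compound 2 `CCOC(=O)CCCCCOc1cccc(CN(C(=O)c2ccc(-c3ccncc3)cc2)C(C)C)c1` gives > 26000 nM as its reading, again a limit. Compound 1 `CC(C)N(Cc1cccc(OCCCCCC(=O)O)c1)C(=O)c1ccc(-c2ccco2)cc1` gives > 26000 nM as its reading, likewise a limit. Going by the values given here, the series so far therefore offers only the limit of > 26000 nM in this assay, at which 3 of the 3 values shown sit, and no number to work from, so compound 3 has no rank among the three.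

Compound 4 `CCOC(=O)CCCCCOc1cccc(CN(C(=O)c2ccc(-c3ccco3)cc2)C(C)C)c1` carries furan-2-yl in place of furan-3-yl on an aromatic carbon, para to a large group, and the counted change is furan-2-yl in place of furan-3-yl on an aromatic carbon with the same atoms joined differently. Among the compounds with values here, the only measured step at this place is a step that the two limits leave unreadable from compound 2 to compound 3 and it gives no size to carry over. No step beyond the usual scatter is therefore expected in this assay and no direction can be given for one. The expected step is a number no higher from compound 3 to compound 4 (the limit leaves the size open) on this estimate. Compound 4 is estimated at 26000 nM with an expected range from 12000 nM to 50000 nM and will most likely be reported only as a limit again.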

Compound 4, half-maximal effective concentration: > 26000 nM
Compound 4 was reported as a limit; the forecaster's own chance of this, stated with the estimate: 85%; the middle value lies on the limit itself.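

In this assay compound 4 gives > 26000 nM, which is a limit and not a number. The steps to compound 4 from compound 1, compound 2 and compound 3 therefore cannot be read, and the series rests on one value: the limit of > 26000 nM in this assay, at which 4 of the 4 values shown sit.

The compounds shown leave open whether furan-2-yl, furan-3-yl, pyridin-4-yl or ethyl in place of hydrogen changes this reading at all.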